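Acyl group exchange in a two-compound series

The source may report more compounds than this note shows. Statements on the series, on what has been measured and on what is new or still open speak of the compounds shown alone.

Values in a functional assay on SU-DHL-6 cells (Homo sapiens) for antiproliferative activity, read by MTT assay; a higher number here means a weaker inhibitor, a lower number a stronger inhibitor:
compound 1 (`COc1ncc(-c2ccc3ncnc(N[C@H]4CCCN(C(=O)C(F)(F)F)C4)c3c2)cc1C#N`): 210 nM
compound 2 (`COc1ncc(-c2ccc3ncnc(N[C@H]4CCCN(C(=O)C5CCN(C)CC5)C4)c3c2)cc1C#N`): 420 nM

Among the compounds with values here, the only measured step reaching compound 2 is a 2.0-fold higher number from compound 1 to compound 2 (0.30 log units; within the scatter), so it stands level with the one other measured compound. Compound 3 (`COc1ncc(-c2ccc3ncnc(N[C@H]4CCCN(C(=O)c5coc([N+](=O)[O-])c5)C4)c3c2)cc1C#N`) carries 5-nitrofuran-3-yl in place of 1-methylpiperidin-4-yl on a carbonyl carbon. Nothing else changes.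

Within the data shown here, the same carbonyl carbon is the site of the single measured step that bears on this change. That step, a 2.0-fold higher number from compound 1 to compound 2 (0.30 log units; within the scatter), exchanged trifluoromethyl for 1-methylpiperidin-4-yl and gave no shift beyond the scatter. It is thin evidence, as no five-membered aromatic ring has yet been measured at this place. In this assay no step beyond the scatter is therefore expected, and no direction can be assigned with any confidence. The expected step, an estimate only, is a 1.4-fold lower number from compound 2 to compound 3 (0.15 log units; within the scatter). Compound 3 is estimated at 300 nM, with an expected range from 90 nM to 1000 nM.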

Compound 3, half-maximal inhibitory concentration: 140 nM
Compound 3: middle estimate off by 2.1-fold (0.33 log units), on the high side; the measured number falls inside the stated range.
By their numbers in this assay, from the lowest: compounds 3, 1 and 2 (each within the scatter of the next, the first and the last beyond it).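

In this assay, the carbonyl carbon on the amide-type nitrogen in a ring now shows its first step beyond the scatter: a 3.0-fold lower number from compound 2 to compound 3 (0.48 log units; beyond the scatter), a modest change on exchanging 1-methylpiperidin-4-yl for 5-nitrofuran-3-yl. The second new step, a 1.5-fold lower number from compound 1 to compound 3 (0.18 log units; within the scatter), stays within the scatter, so 5-nitrofuran-3-yl and trifluoromethyl cannot be told apart here, and compound 1 is not separated from either of the other two compounds; only compound 2 and compound 3 are resolved, and a five-membered aromatic ring is tolerated at this place. No measurement among the compounds shown accounts for the step from the piperidine to the nitrofuran.

Still open, as far as these compounds go, is whether the lower number of compound 3 goes with the nitro group or with the furan ring, a question that an unsubstituted furan-3-yl group or a phenyl ring on the same carbonyl carbon would help to settle. From the compounds shown here alone, with a single cell line as the read-out, it is also open whether this step holds in other cell lines.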